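Changing the Amine Side Group on a Shared Receptor Core

A few compounds are considered here, and "the series" means these few. Any claim that something is new, unique, unknown or untested is made for them only; others in the source may bear on it.

Three measured compounds share one core and differ only in the amine-bearing group on an oxygen on an aromatic ring. Compound 1 `CN1CCC(Oc2ccc(-c3nc4ccc(Oc5ccc(Cl)cc5)cc4o3)cc2)CC1` gives 19.5% in an assay on isolated protein for inhibition of advanced glycosylation end product-specific receptor (Homo sapiens), read by FRET, with stated times of 30 min and 1 h, tested at 4 uM; on this read-out higher numbers stand for more inhibition at the one concentration tested (going by the name of the read-out) and lower numbers for less inhibition. Compound 2 `CC(C)N1CCC(Oc2ccc(-c3nc4ccc(Oc5ccc(Cl)cc5)cc4o3)cc2)CC1` gives 12.7% in this assay, the second highest of the three numbers, within the scatter of compound 1 and beyond it from compound 3. Compound 3 `CCN1CCC(COc2ccc(-c3nc4ccc(Oc5ccc(Cl)cc5)cc4o3)cc2)CC1` gives 2.1% in this assay. The step of a number 6.8 percentage points lower from compound 1 to compound 2 (within the scatter) was within the scatter, whereas a number 10.6 percentage points lower from compound 2 to compound 3 (beyond the scatter) and a number 17.4 percentage points lower from compound 1 to compound 3 (beyond the scatter) were modest drops.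

Compound 4 `N[C@@H]1CCN(CCCOc2ccc(-c3nc4ccc(Oc5ccc(Cl)cc5)cc4o3)cc2)C1` differs from compound 2 in one place: 3-(3-aminopyrrolidin-1-yl)propyl in place of 1-isopropylpiperidin-4-yl on an oxygen on an aromatic ring. The closest measured guide is a number 10.6 percentage points lower from compound 2 to compound 3 (beyond the scatter), where the 1-isopropylpiperidin-4-yl group gave way to (1-ethylpiperidin-4-yl)methyl and the number fell. Compound 4 carries a longer chain and a different ring, so a modest drop is expected, a number 6.7 percentage points lower from compound 2 to compound 4 (within the scatter). Compound 4 is therefore estimated at 6%, within a range from -4% to 18%.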

Compound 4, a percentage reported as inhibition, at one concentration (the size of the read-out at that concentration, not a potency): 19.6%
The estimate for compound 4 lay 13.6 percentage points below the measured number; measured number above the stated range.
By their numbers in this assay, from the lowest: compound 3; then compounds 2, 1 and 4 (each within the scatter of the next).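

Compound 4 shows that a 3-(3-aminopyrrolidin-1-yl)propyl group, with its open chain and five-membered ring, can replace the piperidine groups on this oxygen on an aromatic ring while the number stays within the scatter of theirs (a number 0.1 percentage points higher from compound 1 to compound 4 (within the scatter); a number 6.9 percentage points higher from compound 2 to compound 4 (within the scatter)). The same group stands clearly apart from compound 3 (a number 17.5 percentage points higher from compound 3 to compound 4 (beyond the scatter)), so in this assay a longer link between this oxygen and the amine does not always go with a lower number. No measurement on hand accounts for these differences.

Compound 4 changes the chain, the ring and the amine at once, so the compounds shown cannot say which of these matters. A 3-(dimethylamino)propyl group or the opposite stereoisomer of the 3-aminopyrrolidine would remain to be compared at this position.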